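This account rests on a few compounds, and the source may have more. Where it says the series, first, only, none or still open, it means among the compounds named here.

Measured compounds:
compound 1, `O=C(NCc1ccccc1)c1cc(Oc2ccc(/C=C/c3ccccn3)cc2)ccn1`, 18800 nM
compound 2, `CC(C)NC(=O)c1cc(Oc2ccc(/C=C/c3ccccn3)cc2)ccn1`, 21400 nM

In a functional assay on A549 cells (Homo sapiens) for antiproliferative activity, read by CCK-8 assay, with a stated time of 48 h (on this read-out lower numbers stand for stronger inhibition and higher numbers for weaker inhibition), compound 2 gives the highest of the two numbers; its nearest neighbour is compound 1, and the step of a 1.1-fold higher number from compound 1 to compound 2 (0.06 log units; within the scatter) lies within the scatter, so the two cannot be ordered. Compound 3, `O=C(NC1CCCCC1)c1cc(Oc2ccc(/C=C/c3ccccn3)cc2)ccn1`, is the next compound, and it differs from compound 2 in one place: cyclohexyl in place of isopropyl on an amide-type nitrogen. Within the data shown here, the only measured step that bears on this change is a 1.1-fold higher number from compound 1 to compound 2 (0.06 log units; within the scatter), which exchanged one group for another on the same amide-type nitrogen and produced no movement beyond the scatter. Exchanging isopropyl for cyclohexyl at that nitrogen is expected to behave alike, giving a step of a 1.1-fold lower number from compound 2 to compound 3 (0.03 log units; within the scatter). The value of compound 3 in this assay is therefore estimated at 20000 nM, with a range from 10000 nM to 40000 nM.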

Compound 3, half-maximal inhibitory concentration: 12500 nM
Compound 3: middle estimate off by 1.6-fold (0.20 log units), on the high side; the range from low to high includes it.
By their numbers in this assay, from the lowest: compounds 3, 1 and 2 (each within the scatter of the next).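

In this assay, a third group on the amide-type nitrogen, cyclohexyl, still gives no movement that can be read: the change is a 1.7-fold lower number from compound 2 to compound 3 (0.23 log units; within the scatter) against isopropyl and a 1.5-fold lower number from compound 1 to compound 3 (0.18 log units; within the scatter) against benzyl. The earlier pair compared only benzyl and isopropyl; this result adds a non-aromatic ring of six carbons in place of a three-carbon group with no ring, and compound 1, compound 2 and compound 3 still cannot be ordered. No measurement is available that would explain this flat result.

The compounds shown leave open whether an amine, a carboxylic acid or a longer chain on this nitrogen would move the number beyond the scatter. They also leave open whether a change elsewhere on the shared core would do so.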